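From Methyl to Trifluoromethyl on the Outer Phenyl Ring

The source may report more compounds than this note shows. Statements on the series, on what has been measured and on what is new or still open speak of the compounds shown alone.

Three compounds share one core and differ only in a single group on a phenyl ring. Compound 1 `O=C1C=CC2(C=C1)OCC(=O)N2c1nc(-c2ccc3ccccc3c2)nn1-c1ccc(Cl)cc1` carries a chloro there and, in a functional assay on MDA-MB-231 cells (Homo sapiens) for antiproliferative activity, with a stated time of 5 days (on this read-out lower numbers stand for stronger inhibition and higher numbers for weaker inhibition), compound 1 gives 70 nM. Compound 2 `O=C1C=CC2(C=C1)OCC(=O)N2c1nc(-c2ccc3ccccc3c2)nn1-c1ccccc1` carries hydrogen instead, and in this assay compound 2 gives 70 nM; the step of no change at the digits printed from compound 1 to compound 2 (within the scatter). Compound 3 `Cc1ccc(-n2nc(-c3ccc4ccccc4c3)nc2N2C(=O)COC23C=CC(=O)C=C3)cc1` carries a methyl, and in this assay compound 3 gives 30 nM, the lowest of the three numbers, with a 2.3-fold lower number from compound 1 to compound 3 (0.37 log units; beyond the scatter) and a 2.3-fold lower number from compound 2 to compound 3 (0.37 log units; beyond the scatter).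

Compound 4 `O=C1C=CC2(C=C1)OCC(=O)N2c1nc(-c2ccc3ccccc3c2)nn1-c1ccc(C(F)(F)F)cc1` has not yet been measured. Its change from compound 3 is trifluoromethyl in place of methyl on an aromatic carbon. Among the compounds with values here, no measured step involves a trifluoromethyl, so the nearest guides are the two steps into compound 3, each modest, and the flat step from compound 1 to compound 2. Together they show that changing this one group moves the number only a little in either direction, so a modest step is expected here, most likely back toward the values of compound 1 and compound 2. The estimate for compound 4 is 50 nM, with a range from 20 nM to 150 nM, meaning an expected step of a 1.7-fold higher number from compound 3 to compound 4 (0.22 log units; within the scatter).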

Compound 4, half-maximal inhibitory concentration: 70 nM
Estimate against measurement, compound 4: 1.4-fold (0.15 log units) below; measured number inside the range.
By their numbers in this assay, from the lowest: compound 3; then compounds 1, 2 and 4 (each within the scatter of the next).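

In this assay the trifluoromethyl group does not keep the lower number seen with methyl: the change gives a 2.3-fold higher number from compound 3 to compound 4 (0.37 log units; beyond the scatter) even though both groups sit at the same place, para to a large group. Set against the other two compounds, trifluoromethyl gives no change at the digits printed from compound 2 to compound 4 (within the scatter) and no change at the digits printed from compound 1 to compound 4 (within the scatter) so hydrogen, chloro and trifluoromethyl all read alike at this position, and the methyl of compound 3 is the one group of the four that stands apart. Nothing measured here explains why methyl alone separates from the other three groups.

On these data alone, with only four groups tested at this position, it remains open whether the lower number belongs to methyl alone or is shared by close relatives such as an ethyl or a methoxy group. Also open is what a group carrying an amine or a carboxylic acid would do at the same place, since nothing shown here points to how such groups would read in this assay.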